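A few compounds are considered here, and "the series" means these few. Any claim that something is new, unique, unknown or untested is made for them only; others in the source may bear on it.

Compound 1 `CC(CC(C)(C)C)Oc1cccc2ccc(N3CCCCC3)nc12` in a functional assay on IMR-32 cells with melanin-concentrating hormone receptor 1 (Homo sapiens) as the target, read by fluorescence (a higher number here means a weaker inhibitor, a lower number a stronger inhibitor), reaches only the limit of the assay, > 10000 nM, and so its strength is not a measured number. Compound 1 sits at the limit of > 10000 nM in this assay, at which 1 of the 2 values shown sits. Compound 2 `CCC(CC)C(C)Oc1cccc2ccc(N)nc12` gives 1300 nM in this assay. Compound 3 `CC(CC(C)(C)C)Oc1cccc2ccc(N3CCCC3)nc12` has not yet been measured; it differs from compound 1 by pyrrolidin-1-yl in place of piperidin-1-yl on an aromatic carbon. Since compound 1 offers only a limit, the step of an at least 1.2-fold lower number from compound 1 to compound 3 (0.09 log units; that floor lies within the scatter) is expected to be small, with its direction left open by these two values. Compound 3 is expected to give about 8000 nM in this assay, between 2000 nM and 30000 nM.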

Compound 3, half-maximal inhibitory concentration: > 10000 nM
Compound 3: no number, only a limit; the forecaster's own chance of this, stated with the estimate: 55%; middle value at least 1.2-fold (0.09 log units) away from the limit.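

Among these compounds, compound 3, like compound 1, reaches only a limit in this assay, so no step between the two can be read. The compounds shown leave open whether pyrrolidin-1-yl in place of piperidin-1-yl changes the number at all.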